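Trifluoromethoxy in place of methoxy on the shared core

A few compounds are considered here, and "the series" means these few. Any claim that something is new, unique, unknown or untested is made for them only; others in the source may bear on it.

Compound 1, `COc1ccc(N(C(=O)CN2C=CN(c3ccccc3)C(=O)C(Cc3n[nH]c4ccccc34)C2=O)C(C)C)cc1`, gives 708 nM in a functional assay on CHO cells for agonist activity at Melanocortin receptor 4 (Homo sapiens), read by a luciferase reporter, with a stated time of 4 h (on this read-out higher numbers stand for an effect only at larger amounts of compound and lower numbers for an effect already at smaller amounts), the lowest of the two single numbers available. Compound 2, `COc1ccc(N(C(=O)CN2C=CN(c3cccnc3)C(=O)C(Cc3n[nH]c4ccccc34)C2=O)C(C)C)cc1`, gives 2880 nM in this assay; the change of pyridin-3-yl in place of phenyl on an amide-type nitrogen in a ring brings a 4.1-fold higher number from compound 1 to compound 2 (0.61 log units; beyond the scatter). Compound 3, `CC(C)N(C(=O)CN1C=CN(c2ccccc2)C(=O)C(Cc2n[nH]c3ccccc23)C1=O)c1ccc(O)cc1`, gives 1000 nM; 1000 nM; 31600 nM; > 30000 nM (4 entries) in this assay. The last of these entries is a limit of the assay and not a number. The wide spread of the repeats, (the several entries of compound 3 in this assay, 1000 nM; 1000 nM; 31600 nM; > 30000 nM (4 entries)), shows how far repeated measurements of this kind can drift.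

Compound 4, `CC(C)N(C(=O)CN1C=CN(c2ccccc2)C(=O)C(Cc2n[nH]c3ccccc23)C1=O)c1ccc(OC(F)(F)F)cc1`, differs from compound 1 by trifluoromethyl in place of methyl on an oxygen on an aromatic ring. Among the compounds with values here, no measured step touches this oxygen substituent; the one measured step sits elsewhere on the core and is modest, so it gives no guide here. The step from compound 1 to compound 4 in this assay is therefore expected to be a 1.3-fold higher number from compound 1 to compound 4 (0.10 log units; within the scatter), within the scatter. For compound 4 the estimate in this assay is 900 nM, with a range from 300 nM to 3000 nM.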

Compound 4, half-maximal effective concentration: 151 nM
Beside the measured number, compound 4's estimate is 6.0-fold (0.78 log units) above it; measured number below the stated range.
By their numbers in this assay, from the lowest: compound 4; then compound 1; then compound 2.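

The oxygen substituent on the aromatic ring proves to be a place where the read-out responds: in this assay, trifluoromethyl in place of methyl gives a 4.7-fold lower number from compound 1 to compound 4 (0.67 log units; beyond the scatter). The only step readable before this, pyridin-3-yl in place of phenyl on an amide-type nitrogen in a ring, went towards a higher number, so this is the first change shown that brings an effect at smaller amounts of compound. This step lies beyond the usual scatter, yet it rests on one pair of compounds, and repeats on this series can drift far: the several entries of compound 3 in this assay, 1000 nM; 1000 nM; 31600 nM; > 30000 nM (4 entries).

On these data alone, it remains open whether an ethyl or a difluoromethyl group on the same oxygen would lower the number as well. Also open, as far as these compounds go, is whether pyridin-3-yl in place of phenyl would raise the number as much with trifluoromethoxy present.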